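Methyl on the pendant phenyl across two isomeric cores

The source may hold more compounds than are shown below. What is called first, only, known or untested is meant among the compounds shown, and "the series" means these compounds.

Compound 1 `O=C(Nc1ccc(Oc2ccnc3[nH]ccc23)c(F)c1)c1ccc(-c2ccccc2)cn1` gives 760 nM in a functional assay on PC-3 cells (Homo sapiens) for cytotoxicity, read by MTT assay, with a stated time of 72 h; a lower number here means a stronger inhibitor, a higher number a weaker inhibitor. Compound 2 `Cc1ccc(-c2ccc(C(=O)Nc3ccc(Oc4ccnc5[nH]ccc45)c(F)c3)nc2)cc1` carries methyl in place of hydrogen on an aromatic carbon and gives 2640 nM in this assay, a step of a 3.5-fold higher number from compound 1 to compound 2 (0.54 log units; beyond the scatter). Compound 3 `O=C(Nc1ccc(Oc2ccnc3[nH]ccc23)c(F)c1)c1cc(-c2ccccc2)ccn1` has the same atoms as compound 1 joined differently; the difference between the two cores is not broken down here. In this assay compound 3 gives only a limit, > 10000 nM, which is the limit of > 10000 nM in this assay, at which 1 of the 3 values shown sits. Compound 4 `Cc1cccc(-c2ccnc(C(=O)Nc3ccc(Oc4ccnc5[nH]ccc45)c(F)c3)c2)c1` is compound 3 with methyl in place of hydrogen on an aromatic carbon; here the methyl sits meta to a large group, whereas in compound 2 it sits para, so this is the same kind of change, not the same. The step from compound 1 to compound 2 was a 3.5-fold higher number from compound 1 to compound 2 (0.54 log units; beyond the scatter), and compound 3 already sits at the limit. The expected step is a step that the limit leaves unreadable from compound 3 to compound 4. Compound 4 is therefore estimated at 20000 nM, between 8000 nM and 60000 nM, most likely reported again only as a limit.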

Compound 4, half-maximal inhibitory concentration: 860 nM
Compound 4: middle estimate off by 23-fold (1.37 log units), on the high side, and the stated range ends above it.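

The new step is an at least 11-fold lower number from compound 3 to compound 4 (1.06 log units; beyond the scatter) in this assay, and the effect of the change does not carry from one core to the other: the same change on two cores in this assay, a 3.5-fold higher number (0.54 log units; beyond the scatter) from compound 1 to compound 2 and an at least 11-fold lower number (1.06 log units; beyond the scatter) from compound 3 to compound 4, at least 40-fold (1.60 log units) apart, beyond the scatter of two such steps. From the compounds shown here alone, compound 3 gives only a limit, > 10000 nM, so the full size of that step remains unknown. The pair of steps does not separate the core from the place of the methyl, which sits meta to a large group in compound 4 but not in compound 2.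

Open, going by these compounds, is how a 3-methylphenyl group would behave on the core of compound 1. Also open, on these data alone, is whether methoxy, chlorine or an amine at the same place on the phenyl would follow methyl on either core.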